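A pyridinyl arm replaces acetamido on compound 2

The source may hold more compounds than are shown below. What is called first, only, known or untested is meant among the compounds shown, and "the series" means these compounds.

In an assay on CHO-K1 cells for displacement of a labelled ligand from adenosine receptor A1 (Homo sapiens), read by scintillation counting, with a stated time of 60 min (a lower number here means a stronger inhibitor, a higher number a weaker inhibitor), compound 2 `CC(=O)Nc1ccc(/C=N/Nc2nc(N)c3ncn([C@@H]4O[C@H](CO)[C@@H](O)[C@H]4O)c3n2)cc1` shows only a limit, > 10000 nM, so its true number is not known; it sits at the limit of > 10000 nM in this assay, at which 1 of the 2 values shown sits. Compound 1 `Nc1nc(N/N=C/c2ccc(OCc3ccc(F)cc3)cc2)nc2c1ncn2[C@@H]1O[C@H](CO)[C@@H](O)[C@H]1O` carries (4-fluorobenzyl)oxy where compound 2 carries acetamido. In this assay compound 1 gives 70 nM, and the step of an at least 140-fold higher number from compound 1 to compound 2 (2.15 log units; beyond the scatter) was large. Compound 3 `Nc1nc(N/N=C/c2ccc(-c3ccccn3)cc2)nc2c1ncn2[C@@H]1O[C@H](CO)[C@@H](O)[C@H]1O` carries pyridin-2-yl in place of acetamido on an aromatic carbon, which again removes the acetamido. Because an at least 140-fold higher number from compound 1 to compound 2 (2.15 log units; beyond the scatter) rests on the same removal, run in reverse, the step of an at least 33-fold lower number from compound 2 to compound 3 (1.52 log units; beyond the scatter) is expected to be large and towards a lower number. Compound 3 is therefore estimated at 300 nM, between 50 nM and 3000 nM.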

Compound 3, inhibition constant: 7540 nM
For compound 3 the middle estimate is 25-fold (1.40 log units) below the measured one, and the stated range ends below it.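

In this assay, replacing acetamido with an aromatic ring does not by itself recover the strength of compound 1: the change to pyridin-2-yl gives an at least 1.3-fold lower number from compound 2 to compound 3 (0.12 log units; that floor lies within the scatter), while the comparison with (4-fluorobenzyl)oxy gives a 110-fold higher number from compound 1 to compound 3 (2.03 log units; beyond the scatter). So at this position, having a ring in place of acetamido is not enough. The value of compound 2 is a limit of the assay, not a number: the limit of > 10000 nM in this assay, at which 1 of the 3 values shown sits.

Which part of (4-fluorobenzyl)oxy matters remains open: the fluorine, the oxygen link or the benzyl portion. A plain benzyloxy or phenyl group in the same place would help separate these.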